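Replacing a Carboxyphenyl Arm with a Methyl Group

This account rests on a few compounds, and the source may have more. Where it says the series, first, only, none or still open, it means among the compounds named here.

Compound 1 `O=C(O)c1ccccc1COc1ccc(OCCOCCNC2CCCC2)cc1` was tested in a functional assay on SK-OV-3 cells (Homo sapiens) for inhibition, read by CCK-8 assay, with a stated time of 70 h; a higher number here means a weaker inhibitor, a lower number a stronger inhibitor. In this assay compound 1 gives only a limit of the assay, > 100000 nM, and no number. This is the reading recorded as the limit of > 100000 nM in this assay, at which 1 of the 2 values shown sits, so where compound 1 stands on the numbers shown cannot be placed more exactly than that limit. One other compound, compound 2 `c1ccc2cc(OCCOCCNC3CCCC3)ccc2c1`, has a number in this assay: compound 2 gives 40600 nM. Among the compounds with values here, these two compounds differ in more than one place, so no single measured step links them.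

Compound 3 `CCOc1ccc(OCCOCCNC2CCCC2)cc1` has not yet been measured. It differs from compound 1 in one place: methyl in place of 2-carboxyphenyl on a saturated chain carbon bound to an oxygen on an aromatic ring. The rest of the molecule, with its ether chain and the pyrrolidine-bearing amine, is unchanged.

With compound 1 at a limit, the size of the step can only be guessed. As far as these compounds go, a step of an at least 1.6-fold lower number from compound 1 to compound 3 (0.22 log units; that floor lies within the scatter) is expected, toward a stronger inhibitor, though whether it exceeds the usual scatter remains open. Compound 3 is expected to sit near 60000 nM in this assay, within a range from 20000 nM to 200000 nM.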

Compound 3, half-maximal inhibitory concentration: 90500 nM
Compound 3: middle estimate off by 1.5-fold (0.18 log units), on the low side; the measured number falls inside the stated range.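

Compound 3 gives this position its first step. In this assay methyl in place of 2-carboxyphenyl on a saturated chain carbon bound to an oxygen on an aromatic ring gives an at least 1.1-fold lower number from compound 1 to compound 3 (0.04 log units; that floor lies within the scatter). The change removes 9 heavy atoms, including an aromatic ring and a hydrogen-bond donor, and compound 3 gives 90500 nM, so a readable number does not depend on keeping that arm. This does not show that the change made a real difference, since the floor of the step lies within the scatter, and that floor is all that can be read because compound 1 stands at a limit and not at a number: the limit of > 100000 nM in this assay, at which 1 of the 3 values shown sits.

As far as these compounds go, the true size of the step remains open, and so does the question of whether anything at this position moves the number beyond the scatter. The compounds shown also do not separate the aromatic ring of the arm from its carboxylic acid, a question that a plain benzyl group or a methyl ester at the same place would bear on.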